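Hydroxy Added to the Fused Ring of a Weak Cytotoxin

A few compounds are considered here, and "the series" means these few. Any claim that something is new, unique, unknown or untested is made for them only; others in the source may bear on it.

Measured compounds:
compound 1, `Oc1cc(O)c2nc(-c3ccc(O)c(O)c3)sc2c1`, 41300 nM in a functional assay on MCF7 cells (Homo sapiens) for cytotoxicity; a lower number here means a stronger inhibitor, a higher number a weaker inhibitor;
compound 2, `Oc1ccc(-c2nc3cc(O)ccc3s2)cc1`, 41400 nM in this assay.

Compound 2, in this assay, gives 41400 nM, and compound 1 gives 41300 nM; the two numbers sit within the scatter of each other, so neither compound can be placed ahead of the other. Both are weak inhibitors. Compound 3, `Oc1ccc(-c2nc3cc(O)c(O)cc3s2)cc1`, has not yet been measured. It differs from compound 2 by one change: hydroxy in place of hydrogen on an aromatic carbon. For the measured compounds named here, no measured pair in this set carries that change alone, so nothing here indicates how large a step it brings. Given that compound 1, which carries two further hydroxy groups, gives 41300 nM, a step from compound 2 to compound 3 that stays within the scatter, or drifts only slightly toward a lower number, is expected, that is a 1.2-fold lower number from compound 2 to compound 3 (0.07 log units; within the scatter). Compound 3 is therefore estimated to give 35000 nM, with a likely range from 12000 nM to 100000 nM.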

Compound 3, half-maximal inhibitory concentration: 8400 nM
Compound 3: the middle estimate sits 4.2-fold (0.62 log units) above what was measured; measured number outside the range, below it.
By their numbers in this assay, from the lowest: compound 3; then compounds 1 and 2 (each within the scatter of the next).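

Hydroxy in place of hydrogen on an aromatic carbon of the fused system, ortho to a hydroxy group, brings a 4.9-fold lower number from compound 2 to compound 3 (0.69 log units; beyond the scatter) in this assay and so lies beyond the scatter. For the compounds shown here, the earlier compounds differed in more than one place and gave no step, so this is the first sign that this carbon responds to a single change, though the step is modest and compound 3 rests on one pair. Nothing available explains why the added hydroxy goes with a lower number.

The compounds shown leave open whether a methoxy group, an amine or a fluorine atom on this carbon would give a step of similar size. They also leave open whether hydroxy here would bring the same step without the hydroxy group ortho to it.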